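The source may hold more compounds than are shown below. What is called first, only, known or untested is meant among the compounds shown, and "the series" means these compounds.

Measured in a functional assay on A549 cells (Homo sapiens) for antiproliferative activity, read by MTT assay, with a stated time of 72 h; a lower number here means a stronger inhibitor, a higher number a weaker inhibitor:
- Compound 1 `NC1=NC2(CCSCC2)N(OCCCOc2cccc(Cl)c2Cl)C(N)=N1`: 1 nM
- Compound 2 `NC1=NC2(CCSCC2)N(OCCCOc2ccccc2Br)C(N)=N1`: 40 nM
- Compound 3 `NC1=NC2(CCSCC2)N(OCCCOc2ccccc2Cl)C(N)=N1`: 80 nM

Compound 3 stands level with compound 2, since the step of a 2.0-fold higher number from compound 2 to compound 3 (0.30 log units; within the scatter) is small, while the step of an 80-fold higher number from compound 1 to compound 3 (1.90 log units; beyond the scatter) is large. Compound 4 `NC1=NC2(CCSCC2)N(OCCCOc2cccc(Br)c2)C(N)=N1` differs from it as follows: 3-bromophenyl in place of 2-chlorophenyl on an oxygen on a saturated carbon. Among the measured compounds shown here, this places 3-bromophenyl in place of 2-chlorophenyl, a group that no measured compound carries. The step of a 2.0-fold higher number from compound 2 to compound 3 (0.30 log units; within the scatter) suggests little from exchanging the halogen alone, but the step of a 40-fold higher number from compound 1 to compound 2 (1.60 log units; beyond the scatter) shows that changing the aromatic group can matter greatly. A moderate move towards a lower number is therefore expected, though with wide uncertainty. The estimated step is a 2.7-fold lower number from compound 3 to compound 4 (0.43 log units; beyond the scatter). For compound 4 the estimate is 30 nM, with an expected range from 5 nM to 200 nM.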

Compound 4, half-maximal inhibitory concentration: 50 nM
For compound 4 the middle estimate is 1.7-fold (0.22 log units) below the measured one; the measured number falls inside the stated range.
By their numbers in this assay, from the lowest: compound 1; then compounds 2, 4 and 3 (each within the scatter of the next).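

In this assay, 3-bromophenyl on this oxygen cannot be told apart from the two other phenyl groups carrying one halogen, with a 1.6-fold lower number from compound 3 to compound 4 (0.20 log units; within the scatter) and a 1.3-fold higher number from compound 2 to compound 4 (0.10 log units; within the scatter) both inside the scatter. Among the compounds shown, only compound 1 stands apart, and its 2,3-dichlorophenyl group keeps a large lead here too (a 50-fold higher number from compound 1 to compound 4 (1.70 log units; beyond the scatter)). Nothing measured explains this gap.

From the compounds shown here alone, it remains open whether 3-chlorophenyl or 2,3-dibromophenyl would match compound 1. The effect of an amine on the phenyl group, or a longer chain to the oxygen, is also unknown.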